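Swapping the aryl on the hydrazone: from compound 3 onward

The source may hold more compounds than are shown below. What is called first, only, known or untested is meant among the compounds shown, and "the series" means these compounds.

Measured so far:
Compound 1, `O=C(CSc1nnc(-c2ccncc2)n1-c1ccccc1)N/N=C/c1ccc(Br)cc1`: 4500 nM
Compound 2, `O=C(CSc1nnc(-c2ccncc2)n1-c1ccccc1)N/N=C/c1ccc(F)cc1`: 7040 nM
Compound 3, `O=C(CSc1nnc(-c2ccncc2)n1-c1ccccc1)N/N=C/c1cccc(F)c1`: > 50000 nM

All three compounds share one core and differ only in the aryl group attached to the carbon that is double-bonded to nitrogen. In a functional assay on HCT-116 cells (Homo sapiens) for inhibition, read by MTT assay, with a stated time of 48 h (on this read-out higher numbers stand for weaker inhibition and lower numbers for stronger inhibition), compound 1 gives 4500 nM. Compound 2 gives 7040 nM in this assay, and a 1.6-fold higher number from compound 1 to compound 2 (0.19 log units; within the scatter). Compound 3 stands apart: in this assay it reports only a limit of the assay, > 50000 nM, so its true number is not known. The steps leading to it are an at least 11-fold higher number from compound 1 to compound 3 (1.04 log units; beyond the scatter) and an at least 7.1-fold higher number from compound 2 to compound 3 (0.85 log units; beyond the scatter).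

Compound 4, `O=C(CSc1nnc(-c2ccncc2)n1-c1ccccc1)N/N=C/c1cc(Br)cc(Br)c1O`, is not yet measured. Compared with compound 3 the change is 3,5-dibromo-2-hydroxyphenyl in place of 3-fluorophenyl on a carbon with a double bond to nitrogen. Among the compounds with values here, of the measured steps, the one from compound 1 to compound 3 bears most on this, since it also exchanges a bromo-bearing aryl against the 3-fluorophenyl and was large. Within the data shown here, the hydroxyl and second bromo have no measured counterpart here. Compound 4 is therefore expected to move back toward the numbers of compound 1 and compound 2, an estimated step of an at least 6.2-fold lower number from compound 3 to compound 4 (0.79 log units; beyond the scatter). The estimate for compound 4 in this assay is 8000 nM, expected between 2000 nM and 40000 nM.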

Compound 4, half-maximal inhibitory concentration: 4500 nM
The estimate for compound 4 lay 1.8-fold (0.25 log units) above the measured number; the range from low to high includes it.
By their numbers in this assay, from the lowest: compounds 1, 4 and 2 (each within the scatter of the next). At a limit, above all of these: compound 3.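

In this assay, the carbon with a double bond to nitrogen can carry the 3,5-dibromo-2-hydroxyphenyl group without leaving the range of the 4-bromophenyl and 4-fluorophenyl groups, with no change at the digits printed from compound 1 to compound 4 (within the scatter) and a 1.6-fold lower number from compound 2 to compound 4 (0.19 log units; within the scatter) as the two steps. Against the 3-fluorophenyl group, the same group gives an at least 11-fold lower number from compound 3 to compound 4 (1.04 log units; beyond the scatter) as its step, which leaves compound 3 alone among the four aryl groups shown. The size of that step is only a minimum, and the true gap stays unknown, as one value here is a limit: the limit of > 50000 nM in this assay, at which 1 of the 4 values shown sits.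

The hydroxyl and the second bromine arrive together, so the compounds shown cannot separate what each contributes. They also leave open how this position would respond to a 3-bromophenyl group, or to an aryl ring bearing an amine or a carboxylic acid.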